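Hydroxyethyl Extension on a Chemokine Receptor Antagonist

The source may hold more compounds than are shown below. What is called first, only, known or untested is meant among the compounds shown, and "the series" means these compounds.

Compound 1 `CN(C)c1ncnc(-c2cc(Cl)ccc2NS(=O)(=O)c2ccc(C(C)(C)C)cc2)c1O` in an assay on isolated protein for antagonist activity at C-C chemokine receptor type 9 (Homo sapiens) (on this read-out lower numbers stand for stronger inhibition and higher numbers for weaker inhibition), gives 105 nM.
Compound 2 `CNc1nccnc1-c1cc(Cl)ccc1NS(=O)(=O)c1ccc(C(C)(C)C)cc1` in this assay gives 235 nM.

Within the data shown here, compound 2 holds the higher of the two numbers; its only neighbour is compound 1, separated by a 2.2-fold higher number from compound 1 to compound 2 (0.35 log units; beyond the scatter), a change of the whole aromatic ring. Compound 3 `CC(C)(C)c1ccc(S(=O)(=O)Nc2ccc(Cl)cc2-c2nccnc2NCCO)cc1` differs from compound 2 by hydroxymethyl in place of hydrogen on a saturated chain carbon bound to a nitrogen on an aromatic ring, methylamino becoming (2-hydroxyethyl)amino. Among the measured compounds shown here, no measured step touches this chain, so nothing among the data speaks for a change in either direction. The expected step is a 1.1-fold lower number from compound 2 to compound 3 (0.03 log units; within the scatter), within the scatter. For compound 3 the estimate is 220 nM, with a range from 80 nM to 650 nM.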

Compound 3, half-maximal inhibitory concentration: 34 nM
Compound 3: middle estimate off by 6.5-fold (0.81 log units), on the high side; measured number outside the range, below it.
By their numbers in this assay, from the lowest: compound 3; then compound 1; then compound 2.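

Replacing methylamino with (2-hydroxyethyl)amino gives a 6.9-fold lower number from compound 2 to compound 3 (0.84 log units; beyond the scatter) in this assay, the first sign that this chain can move the number. Compared with the other ring, the result is a 3.1-fold lower number from compound 1 to compound 3 (0.49 log units; beyond the scatter) even though that step changes the whole aromatic ring. No measurement available here explains the gain. From the compounds shown here alone, whether the hydroxyl or simply the longer chain matters stays open, and ethylamino or (2-methoxyethyl)amino could help separate the two. (3-Hydroxypropyl)amino would test whether a still longer chain helps further.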